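Swapping trifluoromethyl for fluoro in compound 1

The source may hold more compounds than are shown below. What is called first, only, known or untested is meant among the compounds shown, and "the series" means these compounds.

Measured in a functional assay on A549 cells (Homo sapiens) for antiproliferative activity, read by MTT assay, with a stated time of 72 h; on this read-out higher numbers stand for weaker inhibition and lower numbers for stronger inhibition:
- compound 1 `CC(C)NC(=N)NC(=N)Nc1ccc(C(F)(F)F)cc1`: 3600 nM
- compound 2 `CC(C)CNC(=N)NC(=N)Nc1ccc(C(F)(F)F)cc1`: 1300 nM

Of these two, compound 1 has the higher number at 3600 nM, which makes it the weaker inhibitor in this assay. Compound 3 `CC(C)NC(=N)NC(=N)Nc1ccc(F)cc1` carries fluoro in place of trifluoromethyl on an aromatic carbon. Among the measured compounds shown here, only one measured step exists, a 2.8-fold lower number from compound 1 to compound 2 (0.44 log units; beyond the scatter), and it is modest. That step is isobutyl in place of isopropyl on an amine nitrogen, a different place in the molecule. It therefore says nothing direct about this swap and only hints at how large a step in this assay can be. The direction stays uncertain, but a somewhat higher number is expected. For compound 3 the expected value is 7000 nM, with an estimated range of 2500 nM to 20000 nM. The estimated step is a 1.9-fold higher number from compound 1 to compound 3 (0.29 log units; within the scatter).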

Compound 3, half-maximal inhibitory concentration: 7500 nM
For compound 3 the middle estimate is 1.1-fold (0.03 log units) below the measured one; the measured number falls inside the stated range.
By their numbers in this assay, from the lowest: compound 2; then compound 1; then compound 3.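

Until now, only the group on the amine nitrogen had been changed. This result shows that the group on the aromatic carbon also affects the outcome in this assay, with a 2.1-fold higher number from compound 1 to compound 3 (0.32 log units; beyond the scatter) when fluoro replaces trifluoromethyl. The step is modest, so the smaller fluoro group gives somewhat weaker inhibition but does not abolish it, and nothing available explains why the number rises.

Among the compounds shown here, with only two groups compared at this position, no trend can be drawn, and it remains open how a chlorine atom, a methoxy group, a nitrile or a plain hydrogen would compare there. From the compounds shown here alone, it is also open whether the same swap would produce a step of similar size when made on compound 2, which carries isobutyl instead of isopropyl.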